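Replacing the acetoxy group of compound 3

The compounds below may be only part of what the source reports. "The series", "measured", "known", "first", "only" and "open" are said of these compounds alone.

Measured in an ADME assay for pharmacokinetics; a lower number here means that the compound disappears faster, a higher number that the compound lasts longer:
- Compound 1 `COC(=O)c1ccc(COC(=O)C2=C(COC(C)=O)CS(=O)(=O)[C@@H]3[C@@H](OC)C(=O)N23)cc1`: < 5 h (a limit)
- Compound 2 `CO[C@H]1C(=O)N2C(C(=O)N(C)CCC(=O)O)=C(COC(C)=O)CS(=O)(=O)[C@H]12`: 24 h
- Compound 3 `CO[C@H]1C(=O)N2C(C(=O)N3CCCC3)=C(COC(C)=O)CS(=O)(=O)[C@H]12`: 16 h

Compound 1 gives no number, only (the limit of < 5 h in this assay, at which 1 of the 3 values shown sits). Among the two real numbers, compound 2 and compound 3 stand level within the scatter. Compound 3 gives 16 h.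

Compound 4 `CO[C@H]1C(=O)N2C(C(=O)N3CCCC3)=C(CSc3nc(=O)c(=O)[nH]n3C)CS(=O)(=O)[C@H]12` keeps the pyrrolidin-1-yl group of compound 3 and changes one place: a group of 10 heavy atoms (4 carbon, 3 nitrogen, 2 oxygen, 1 sulfur; one six-membered aromatic ring with 3 hetero atoms) in place of a group of 4 heavy atoms (2 carbon, 2 oxygen; no ring), on a saturated chain carbon bound to a double-bonded ring carbon. For the measured compounds named here, no measured step touches that place. Going by the values given here, the only step with a number, a 1.5-fold lower number from compound 2 to compound 3 (0.18 log units; within the scatter), lies on a carbonyl carbon, so its size cannot simply be carried over to the new group. With nothing measured at this place, the range has to stay wide. In this assay, no change beyond the scatter is expected, and the expected step is a 1.3-fold lower number from compound 3 to compound 4 (0.12 log units; within the scatter). The half-life of compound 4 is estimated at 12 h, with an expected range from 4 h to 36 h.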

Compound 4, half-life: 20 h
For compound 4 the middle estimate is 1.7-fold (0.22 log units) below the measured one; the range from low to high includes it.
By their numbers in this assay, from the lowest: compounds 3, 4 and 2 (each within the scatter of the next). At a limit, below all of these: compound 1.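

The first change shown on the saturated chain carbon bound to a double-bonded ring carbon replaces the acetoxy group with a group of 10 heavy atoms carrying one six-membered aromatic ring with 3 hetero atoms, and in this assay it gives a 1.3-fold higher number from compound 3 to compound 4 (0.10 log units; within the scatter). With the pyrrolidin-1-yl group kept, this place therefore accepts a much larger group carrying a ring, and the acetoxy group is not required for a half-life at the level of the two compounds already measured with a number. Nothing measured here accounts for this result.

The compounds shown leave open whether the new group behaves the same way alongside the (2-carboxyethyl)(methyl)amino group of compound 2. They also do not tell how an amine, a carboxylic acid or a longer chain at this place would fare in this assay.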